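Methoxy in Place of Methyl: A Small Shift Expected

A few compounds are considered here, and "the series" means these few. Any claim that something is new, unique, unknown or untested is made for them only; others in the source may bear on it.

Compound 2 `Cc1ccccc1N1CCn2c1n[nH]c(=O)c2=O` stands highest of the two numbers measured in a functional assay on A549 cells (Homo sapiens) for antiproliferative activity, with a stated time of 72 h, tested at 10 ug/mL (on this read-out lower numbers stand for a weaker effect and higher numbers for a stronger effect at the one concentration tested), where compound 2 gives 24%. For the measured compounds named here, compound 1 `O=c1[nH]nc2n(c1=O)CCN2c1ccccc1` gives 0% in this assay, and the step of a number 24 percentage points higher from compound 1 to compound 2 (beyond the scatter) is the only measured step. Compound 3 `COc1ccccc1N1CCn2c1n[nH]c(=O)c2=O` differs from compound 2 by methoxy in place of methyl on an aromatic carbon. Going by the values given here, no measured step swaps one substituent for another on that aromatic carbon; the step from compound 1 to compound 2 shows only that a group there can raise the read-out. The step of a number 4 percentage points lower from compound 2 to compound 3 (within the scatter) is therefore expected to be small, possibly within the scatter. Compound 3 is estimated at 20%, with a range from 0% to 45%.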

Compound 3, a percentage reported as inhibition, at one concentration (the size of the read-out at that concentration, not a potency): 0%
Compound 3: middle estimate off by 20 percentage points, on the high side, within the range that was stated.
By their numbers in this assay, from the lowest: compounds 1 and 3 (each within the scatter of the next); then compound 2.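

In this assay, the step of a number 24 percentage points lower from compound 2 to compound 3 (beyond the scatter) shows that the read-out at this aromatic carbon depends on which group sits there. With the step of no change at the digits printed from compound 1 to compound 3 (within the scatter), methoxy reads the same as hydrogen, so the presence of a group on this carbon is not enough on its own, and among these compounds only methyl stands apart. Nothing available explains the difference between methyl and methoxy. From the compounds shown here alone, whether an ethyl group, a chlorine atom or an amine on this carbon would read like methyl or like methoxy remains open.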